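Does Changed Configuration Alter the Cytotoxicity of Compound 1?

The source may report more compounds than this note shows. Statements on the series, on what has been measured and on what is new or still open speak of the compounds shown alone.

- compound 1 `CCOC(=O)[C@@H]1[C@@H](C(=O)OCC)N1C(=O)[C@@H]1CCCN(C(=O)[C@H](CC(C)C)NC(=O)OC(C)(C)C)C1`: > 100000 nM
- compound 2 `CC(C)C[C@H](NC(=O)OC(C)(C)C)C(=O)N1CCC[C@H]1C(=O)N1[C@H](C(=O)OCc2ccccc2)[C@H]1C(=O)OCc1ccccc1`: > 125000 nM

Both entries are limits of the assay rather than exact numbers. The read-out here is a functional assay on J774 cells (Mus musculus) for cytotoxicity, with a stated time of 48 h; on this read-out lower numbers stand for stronger inhibition and higher numbers for weaker inhibition. In this assay compound 1 gives only a limit, > 100000 nM. Compound 2 likewise gives only a limit, > 125000 nM. For the measured compounds named here, compound 1 therefore has no exact position on the scale, and no measured pair shows what a change of configuration does in this assay.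

Compound 3 `CCOC(=O)[C@H]1[C@H](C(=O)OCC)N1C(=O)[C@H]1CCCN(C(=O)[C@H](CC(C)C)NC(=O)OC(C)(C)C)C1` has the same atoms and bonds as compound 1 and differs only in configuration as drawn: the two compounds have the same atoms and bonds and differ only in configuration as drawn: 3 of 4 stereo elements differ; a stereocentre at a saturated ring carbon is drawn S in compound 1 and R in compound 3; a stereocentre at a saturated ring carbon is drawn S in compound 1 and R in compound 3; a stereocentre at a saturated ring carbon is drawn R in compound 1 and S in compound 3. Nothing leaves and nothing enters, but the spatial arrangement at those stereocentres changes.

Going by the values given here, with no measured step to guide it, the expectation is no change beyond the usual scatter, in either direction. The estimated change is a number no higher from compound 1 to compound 3 (the limit leaves the size open). A further limit, rather than an exact number, is the most likely result. For compound 3 the estimated value is 100000 nM, with an expected range from 45000 nM to 200000 nM.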

Compound 3, half-maximal inhibitory concentration: > 100000 nM
Compound 3 gave a limit, no number; the forecaster's own chance of this, stated with the estimate: 85%; the middle value lies on the limit itself.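

For the compounds shown here, compound 3 gives only a limit, so no step from compound 1 to compound 3 can be read, because the two compounds sit at the same limit: the limit of > 100000 nM in this assay, at which 2 of the 3 values shown sit.

As far as these compounds go, whether this change of configuration alters the result in this assay stays open, as does the exact position of each of the three compounds on that scale.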